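The compounds below may be only part of what the source reports. "The series", "measured", "known", "first", "only" and "open" are said of these compounds alone.

Compound 1 `CCC/N=C(\NC#N)Nc1cccnc1` gives 20 mg/kg in a functional assay on the whole organism (blood, strain Wistar-Okamoto) with Rattus norvegicus as the target, with a stated time of 5 days; on this read-out higher numbers stand for an effect only at larger amounts of compound and lower numbers for an effect already at smaller amounts. Compound 2 `CCC(C)/N=C(\NC#N)Nc1cccnc1` gives 20 mg/kg in this assay.

On these two readings compound 2 stands level with compound 1: the step of no change at the digits printed from compound 1 to compound 2 (within the scatter) shows that adding a methyl on the saturated chain carbon made no difference beyond the scatter. Compound 3 `CC1(/N=C(\NC#N)Nc2cccnc2)CCC1` is not yet measured. Its change from compound 2 is 1-methylcyclobutyl in place of sec-butyl on a double-bonded nitrogen. Going by the values given here, only the step from compound 1 to compound 2 bears on it, and that step was flat, so the same part of the shared core has already tolerated one added carbon without a shift in the minimum effective dose. On that ground, in this assay the step of no change at the digits printed from compound 2 to compound 3 (within the scatter) for compound 3 is expected to stay within the scatter. Compound 3 is therefore estimated at 20 mg/kg, with a range from 8 mg/kg to 50 mg/kg.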

Compound 3, minimum effective dose: 50 mg/kg
For compound 3 the middle estimate is 2.5-fold (0.40 log units) below the measured one; low and high end bracket the measured number.
By their numbers in this assay, from the lowest: compounds 1 and 2 (each within the scatter of the next); then compound 3.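

Going by these compounds alone, the group on the double-bonded nitrogen can matter in this assay after all: putting 1-methylcyclobutyl there brings a 2.5-fold higher number from compound 2 to compound 3 (0.40 log units; beyond the scatter) and also a 2.5-fold higher number from compound 1 to compound 3 (0.40 log units; beyond the scatter) and this is the first shift beyond the scatter at this place, with a larger amount of compound now needed for an effect. Compared with sec-butyl, the new group adds a ring and one more carbon together, so this single step cannot say which of the two goes with the shift. Nothing available here explains the shift.

From the compounds shown here alone, it remains open whether cyclobutyl without the methyl, or tert-butyl with no ring, would stay level with compound 2 or move as compound 3 does. Also open, going by these compounds, is how a longer chain, or a chain carrying an ether oxygen, would fare at this place.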